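Nitrooxy in place of hydrogen on compound 2

The source may hold more compounds than are shown below. What is called first, only, known or untested is meant among the compounds shown, and "the series" means these compounds.

Measured so far in a functional assay on cells (Hepatocyte, Rattus norvegicus, strain Wistar), using NADPH; a lower number here means a stronger inhibitor, a higher number a weaker inhibitor
- compound 1 `O=C1OC(C(O)CO)C(OCCCOc2no[n+]([O-])c2S(=O)(=O)c2ccccc2)=C1O` gives 80000 nM
- compound 2 `O=C1OC(C(O)CO)C(OCCCCCCO[N+](=O)[O-])=C1O` gives 80000 nM

Compound 2 stands level with compound 1 on these numbers, with no difference at the digits shown, so neither can be ranked over the other. Compound 3 `O=C1OC(C(O)CO)C(OCCCCC(CO[N+](=O)[O-])O[N+](=O)[O-])=C1O` departs from compound 2 in one place, with nitrooxy in place of hydrogen on a saturated chain carbon bound to two saturated chain carbons. Going by the values given here, the data hold no measured step between compounds that differ in one place, so the size of this change has no direct precedent here. The expectation therefore starts from compound 2 at 80000 nM and from the structural change alone. No step beyond the scatter is expected in this assay in either direction, although the uncertainty is wide with so little to go on. The estimated step runs a 1.3-fold lower number from compound 2 to compound 3 (0.12 log units; within the scatter) and stays within the scatter. Compound 3 is estimated at 60000 nM with an expected range from 20000 nM to 150000 nM as the working figure.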

Compound 3, half-maximal inhibitory concentration in the Hepatocyte assay: 28000 nM
Beside the measured number, compound 3's estimate is 2.1-fold (0.33 log units) above it; measured number inside the range.
By their numbers in the Hepatocyte assay, from the lowest: compound 3; then compounds 1 and 2 (each within the scatter of the next).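

Going by these compounds alone, in the Hepatocyte assay, where compound 2 gives 80000 nM and compound 3 gives 28000 nM, nitrooxy in place of hydrogen on a saturated chain carbon bound to two saturated chain carbons gives a 2.9-fold lower number from compound 2 to compound 3 (0.46 log units; beyond the scatter) and so provides the only measured single-place step, showing that inhibition in this assay responds to a change at this position. In a physicochemical assay for lipophilicity, using the shake flask method, with a stated time of 4 h, at pH 1.0 (on this read-out higher numbers stand for higher lipophilicity and lower numbers for lower lipophilicity), where compound 2 gives 0.86 and compound 3 gives 0.78, the same change gives a number 0.08 log units lower from compound 2 to compound 3 (within the scatter) and leaves this pair unresolved on that read-out, so the two compounds separate in the cell assay but not in the distribution coefficient. No measurement here bears on the reason for the step in either read-out.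

This single pair leaves open whether the step depends on nitrooxy itself or would also appear with another group at this place, such as an amine or a carboxylic acid. It also leaves open whether the same nitrooxy change would give a step of similar size on a longer chain, or on a chain carrying a different terminal group.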